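Adding a Chloro Group to Compound 3

The compounds below may be only part of what the source reports. "The series", "measured", "known", "first", "only" and "open" are said of these compounds alone.

In a functional assay on A549 cells (Homo sapiens) for antiproliferative activity, read by MTT assay, with a stated time of 48 h (a lower number here means a stronger inhibitor, a higher number a weaker inhibitor), compound 1 (`COc1cc(-c2nnc(-c3cn4ccccc4n3)o2)cc(OC)c1OC`) gives 2800 nM as its reading. Compound 2 (`COc1ccc(-c2nnc(-c3cn4cccc(C)c4n3)o2)cc1OC`) gives 10900 nM on the same read-out. Compound 3 (`Cc1cc(Br)c2nc(-c3nnc(-c4ccccc4)o3)cn2c1`) gives 14500 nM as its reading, which lies within the scatter of compound 2 but well beyond the scatter of compound 1, the lower number of that pair.

Compound 4 (`Cc1cc(Br)c2nc(-c3nnc(-c4ccc(Cl)cc4)o3)cn2c1`) keeps the structure of compound 3 except for one place. The change is chloro in place of hydrogen on an aromatic carbon and it sits para to a large group, so that phenyl becomes 4-chlorophenyl. Among the measured compounds shown here, no measured pair in this set differs in a single place, so the data give no direct precedent for this change. Compound 1 at 2800 nM shows only that lower numbers occur among these compounds. The expected step (a 1.6-fold lower number from compound 3 to compound 4 (0.21 log units; within the scatter)) is therefore small, towards a somewhat lower number, and may not clear the scatter. For compound 4 the estimated value is 9000 nM with an expected range from 3500 nM to 22000 nM in this estimate.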

Compound 4, half-maximal inhibitory concentration: 43500 nM
Compound 4: the middle estimate sits 4.8-fold (0.68 log units) below what was measured, outside the stated range (above it).
By their numbers in this assay, from the lowest: compound 1; then compounds 2 and 3 (each within the scatter of the next); then compound 4.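

Among the compounds shown here, the step gives the first single-place comparison in this set: in this assay, chloro in place of hydrogen on an aromatic carbon, para to a large group, brings a 3.0-fold higher number from compound 3 to compound 4 (0.48 log units; beyond the scatter), a modest change but one beyond the scatter, towards weaker inhibition. This place on the phenyl of compound 3 is therefore not indifferent to substitution, and phenyl to 4-chlorophenyl loses activity here rather than gaining it. No measurement on hand bears on why the number rose.

From the compounds shown here alone, it remains open whether this rise is particular to chloro or would also follow from another group at the same place, such as fluoro, an amine or a carboxylic acid. It is also open whether the same change would shift the number similarly on the other compounds shown.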